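This account rests on a few compounds, and the source may have more. Where it says the series, first, only, none or still open, it means among the compounds named here.

Measured in a functional assay on MCF7 cells (Homo sapiens) for inhibition, with a stated time of 48 h, tested at 50 uM; a higher number here means more inhibition of growth at the concentration tested, a lower number less inhibition of growth:
- compound 1 `COc1ccc(/C=C/[C@@](C)(/C=C/c2ccc(O)cc2)CCC=C(C)C)cc1`: 55%
- compound 2 `CC(C)=CCCC(C)(/C=C/c1ccc(O)cc1)/C=C/c1ccc(O)cc1`: 31%

Of these two compounds, compound 2 stands lower, at 31%, and its gap to compound 1 lies beyond the scatter. The next structure, compound 3 `COc1ccc(/C=C/[C@](C)(/C=C/c2ccc(O)cc2)CCC=C(C)C)cc1`, departs from compound 2 by methyl in place of hydrogen on an oxygen on an aromatic ring, which is methyl in place of hydrogen on an oxygen on an aromatic ring.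

Among the measured compounds shown here, only one measured step bears on this change. It is the same exchange run the other way, a number 24 percentage points lower from compound 1 to compound 2 (beyond the scatter), a modest step beyond the scatter. Read in reverse, it points to a rise in this assay of about that size. For the measured compounds named here, the match is not exact, since the stereocentre of compound 3 is drawn in the opposite sense to that of compound 1, and no measurement yet shows what this means for growth inhibition. The expectation is therefore set slightly short of the full measured size and kept wide. The estimate is a number 19 percentage points higher from compound 2 to compound 3 (beyond the scatter), an expected gain. Compound 3 is expected at 50%, with an estimated range from 32% to 68%.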

Compound 3, percent growth inhibition at one concentration: 77%
For compound 3 the middle estimate is 27 percentage points below the measured one; the whole stated range lies below it.
By their numbers in this assay, from the lowest: compound 2; then compound 1; then compound 3.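

The change of hydrogen to methyl on an oxygen on an aromatic ring now shows a much larger effect in this assay than the earlier pair suggested: a number 46 percentage points higher from compound 2 to compound 3 (beyond the scatter) is a large step, whereas the same exchange read from the other pair, a number 24 percentage points lower from compound 1 to compound 2 (beyond the scatter), is modest. The size of the gain from this methyl therefore depends on how the stereocentre at the saturated chain carbon is drawn, and the methyl group alone does not set it. The further gap, a number 22 percentage points higher from compound 1 to compound 3 (beyond the scatter), can be assigned to that stereocentre, because nothing else separates the two structures: the fact that compounds 1 and 3 differ only in the configuration as drawn.

The compounds shown leave open whether an ethyl group or a longer chain on the same oxygen would keep, extend or lose this gain, and whether an amine in place of that oxygen would do the same. They also leave open whether the preference for the configuration of compound 3 holds at other concentrations or in other cells, since all these readings come from one assay at one concentration.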